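Furan-3-yl in place of the hexynyl chain on the shared core

This account rests on a few compounds, and the source may have more. Where it says the series, first, only, none or still open, it means among the compounds named here.

Measured compounds in a functional assay on Z-138 cells (Homo sapiens) for antiproliferative activity, with a stated time of 72 h; on this read-out lower numbers stand for stronger inhibition and higher numbers for weaker inhibition:
compound 1, `CCCCC#Cc1cc([C@@H]2O[C@H](CO)[C@@H](O)[C@H]2O)n2ncnc(N)c12`: 200 nM
compound 2, `Nc1ncnn2c([C@@H]3O[C@H](CO)[C@@H](O)[C@H]3O)cc(-c3ccc(F)cc3)c12`: > 100000 nM
compound 3, `Nc1ncnn2c([C@@H]3O[C@H](CO)[C@@H](O)[C@H]3O)cc(-c3ccccc3F)c12`: 95300 nM

Compound 1 carries a hex-1-yn-1-yl group and gives the lowest number of the values shown. Compound 3, with 2-fluorophenyl at the same aromatic carbon, is its nearest neighbour, and the step is a 480-fold higher number from compound 1 to compound 3 (2.68 log units; beyond the scatter). Compound 2 returns only a limit in this assay, > 100000 nM, and that is the limit of > 100000 nM in this assay, at which 1 of the 3 values shown sits. The step of an at least 500-fold higher number from compound 1 to compound 2 (2.69 log units; beyond the scatter) is therefore a floor. Between the two fluorophenyl compounds the step of an at least 1.0-fold lower number from compound 2 to compound 3 (0.02 log units; that floor lies within the scatter) lies within the scatter.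

Compound 4, `Nc1ncnn2c([C@@H]3O[C@H](CO)[C@@H](O)[C@H]3O)cc(-c3ccoc3)c12`, is not yet measured. It differs from compound 1 in one place: furan-3-yl in place of hex-1-yn-1-yl on an aromatic carbon. Going by the values given here, the only measured steps that bear on this change are the two in which an aromatic ring replaces the hex-1-yn-1-yl group, an at least 500-fold higher number from compound 1 to compound 2 (2.69 log units; beyond the scatter) and a 480-fold higher number from compound 1 to compound 3 (2.68 log units; beyond the scatter), both large losses. Furan-3-yl is again an aromatic ring on that carbon, though a smaller one, so a large rise in the number is expected, with some chance the assay reports only a limit. The expected step is a 150-fold higher number from compound 1 to compound 4 (2.18 log units; beyond the scatter). Compound 4 is estimated at 30000 nM, between 3000 nM and 100000 nM.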

Compound 4, half-maximal inhibitory concentration: 300 nM
Beside the measured number, compound 4's estimate is 100-fold (2.00 log units) above it, outside the stated range (below it).
By their numbers in this assay, from the lowest: compounds 1 and 4 (each within the scatter of the next); then compound 3. At a limit, above all of these: compound 2.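

An aromatic ring on this carbon does not by itself raise the number in this assay, since furan-3-yl and hex-1-yn-1-yl cannot be told apart there (a 1.5-fold higher number from compound 1 to compound 4 (0.18 log units; within the scatter)). Among the aromatic groups shown, the position separates furan-3-yl sharply from 2-fluorophenyl (a 320-fold lower number from compound 3 to compound 4 (2.50 log units; beyond the scatter)), so the large losses seen earlier belong to the two fluorophenyl compounds and not to aromatic rings as a whole. The step from 4-fluorophenyl points the same way but is only a floor (an at least 330-fold lower number from compound 2 to compound 4 (2.52 log units; beyond the scatter)), and the value of compound 2 is a limit: the limit of > 100000 nM in this assay, at which 1 of the 4 values shown sits.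

Ring size and fluorine change together in these steps, so the compounds shown cannot say which of the two separates compound 4 from compounds 2 and 3; unsubstituted phenyl, furan-2-yl and thiophen-3-yl would begin to pull these apart. Going by these compounds, how much further the position reaches also stays open, for example with a shorter alkynyl chain, or with an amine or a carboxylic acid at the end of the hexynyl chain.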